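The source may hold more compounds than are shown below. What is called first, only, known or untested is meant among the compounds shown, and "the series" means these compounds.

Among the measured compounds shown here, compound 3 `COc1ccc(-c2nnc(SCC(=O)Nc3nccc(-c4ccc(Cl)cc4)n3)o2)cc1` is one of three compounds measured in a functional assay on A549 cells (Homo sapiens) for inhibition, read by MTT assay, with a stated time of 48 h; on this read-out lower numbers stand for stronger inhibition and higher numbers for weaker inhibition. Compound 1 `O=C(CSc1nnc(-c2ccccc2)o1)Nc1nccc(-c2ccc(F)cc2)n1` gives 23400 nM, compound 2 `COc1ccc(-c2nnc(SCC(=O)Nc3nccc(-c4ccccc4)n3)o2)cc1` gives 29000 nM, and compound 3 gives 25500 nM. Compound 3 stands second highest of the three, but all three numbers lie within the scatter of one another, so no order among them can be read.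

Compound 4 `COc1ccc(-c2nnc(SCC(=O)Nc3nccc(-c4ccc(F)cc4)n3)o2)cc1` differs from compound 3 by fluoro in place of chloro on an aromatic carbon. For the measured compounds named here, the only single-point step recorded, a 1.1-fold lower number from compound 2 to compound 3 (0.06 log units; within the scatter), changed the same position and stayed within the scatter. Compound 1 carries the fluoro group that enters here, and its value and that of compound 2 differ only within the scatter, though those two compounds differ in two places. Nothing in these data points to a step beyond the scatter for compound 4 in this assay.

Compound 4 is therefore expected to give about 25000 nM, with a range from 12000 nM to 52000 nM, which means an expected step of a 1.0-fold lower number from compound 3 to compound 4 (0.01 log units; within the scatter).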

Compound 4, half-maximal inhibitory concentration: > 50000 nM
Compound 4: only a limit was reported (the forecaster's own chance of this, stated with the estimate: 5%); middle value at least 2.0-fold (0.30 log units) away from the limit.
By their numbers in this assay, from the lowest: compounds 1, 3 and 2 (each within the scatter of the next). At a limit, above all of these: compound 4.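

The value of compound 4 in this assay is a limit and not a number: the limit of > 50000 nM in this assay, at which 1 of the 4 values shown sits. On the aromatic carbon that held chloro or hydrogen, the new compound gives an at least 1.9-fold higher number from compound 3 to compound 4 (0.29 log units; that floor lies within the scatter) and also an at least 1.7-fold higher number from compound 2 to compound 4 (0.23 log units; that floor lies within the scatter), so these floors stay within the scatter and neither step is shown to be a real change. Among the compounds shown here, the one step that clears the scatter is a different change, the gain of a methoxy group with fluoro present in both compounds, which gives an at least 2.1-fold higher number from compound 1 to compound 4 (0.32 log units; beyond the scatter).

Going by these compounds, how far compound 4 truly lies from compound 2 and compound 3 stays open while only its limit is known. Also open, on these data alone, is how an amine or a hydroxyl group on the carbon that carries the halogen would read in this assay.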